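Carboxyphenyl in Place of Carboxypyridinyl on the Cyclopropane

A few compounds are considered here, and "the series" means these few. Any claim that something is new, unique, unknown or untested is made for them only; others in the source may bear on it.

Compound 1 `O=C(O)c1cncc(C2CC2c2ccc(OCc3c(-c4c(Cl)cccc4Cl)noc3C3CC3)cc2Cl)c1` was measured in an assay on isolated protein for agonist activity at Bile acid receptor (Homo sapiens), read by FRET (a higher number here means a larger maximal response, a lower number a smaller maximal response), and gives 103%, while compound 2 `Cn1nc(C(=O)O)c2ccc([C@H]3C[C@](O)(c4ccc(OCc5c(-c6c(Cl)cccc6Cl)noc5C5CC5)cc4Cl)C3)cc21` gives 99%, a number within the usual scatter of it, so the two stand side by side. Compound 3 `O=C(O)c1cccc([C@H]2C[C@@H]2c2ccc(OCc3c(-c4c(Cl)cccc4Cl)noc3C3CC3)cc2Cl)c1` has not yet been measured; it differs from compound 1 in a single spot: 2-(3-carboxyphenyl)cyclopropyl in place of 2-(5-carboxypyridin-3-yl)cyclopropyl on an aromatic carbon. Since compound 1 already reaches 103%, close to the full response of the control, the expected step of a number 6 percentage points lower from compound 1 to compound 3 (within the scatter) is small and not beyond the scatter. Compound 3 is estimated to give 97%, with a range from 78% to 112%.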

Compound 3, largest response reached (reported as efficacy), in percent of the reference or control that the assay uses: 101%
Compound 3: the middle estimate sits 4 percentage points below what was measured, within the range that was stated.
By their numbers in this assay, from the lowest: compounds 2, 3 and 1 (each within the scatter of the next).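

Placing 2-(3-carboxyphenyl)cyclopropyl where 2-(5-carboxypyridin-3-yl)cyclopropyl stood gives a number 2 percentage points lower from compound 1 to compound 3 (within the scatter) in this assay and so shows that, in this pair, the ring nitrogen can be replaced by carbon with the maximal response staying level. No measurement shown offers a cause for this result. The compounds shown leave open whether the response would hold if a tetrazole replaced the carboxylic acid on that ring. They also leave open what a longer chain in place of the cyclopropane would do.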